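From compound 2 to compound 4: a larger side group

The source may hold more compounds than are shown below. What is called first, only, known or untested is meant among the compounds shown, and "the series" means these compounds.

In an ADME assay on the whole organism (Mus musculus, strain CD-1) for pharmacokinetics, at a dose of 10 mg/kg by the oral route (on this read-out higher numbers stand for higher exposure at the dose given and lower numbers for lower exposure), compound 1 (`COc1cccc([C@H](c2cc3cc(Br)ccc3nc2OC)[C@@](O)(CCN(C)C)c2cc(SC)nc(SC)c2)c1F`) gives 8400 ng.h/mL, compound 3 (`COc1nc2ccc(C#N)cc2cc1[C@@H](c1cccc(C)c1F)[C@@](O)(CCN(C)C)c1cc(SC)nc(SC)c1`) gives 2400 ng.h/mL, and compound 2 (`COc1cccc([C@H](c2cc3cc(C#N)ccc3nc2OC)[C@@](O)(CCN(C)C)c2cc(SC)nc(SC)c2)c1F`) gives 1100 ng.h/mL, the lowest of the three numbers. Compound 4 (`CCSc1cc([C@](O)(CCN(C)C)[C@@H](c2cc3cc(C#N)ccc3nc2OC)c2cccc(OC)c2F)cc(SCC)n1`) has not been measured yet, and it differs from compound 2 in one place: a group of 12 heavy atoms (9 carbon, 1 nitrogen, 2 sulfur; one six-membered aromatic ring with 1 hetero atom) in place of a group of 10 heavy atoms (7 carbon, 1 nitrogen, 2 sulfur; one six-membered aromatic ring with 1 hetero atom), on a saturated chain carbon bound to an oxygen on a saturated carbon and two saturated chain carbons.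

Among the measured compounds shown here, no measured step touches this group. Putting cyano in place of bromo gave a 7.6-fold lower number from compound 1 to compound 2 (0.88 log units; beyond the scatter), and putting methyl in place of methoxy gave a 2.2-fold higher number from compound 2 to compound 3 (0.34 log units; beyond the scatter). Both changes lie elsewhere on the molecule, so they show only how far a single change has moved the number among these compounds, not which way this one will go. A step of similar or smaller size is expected in this assay, and the data give no firm direction. The estimated step is a 1.2-fold higher number from compound 2 to compound 4 (0.07 log units; within the scatter). Compound 4 is expected to give about 1300 ng.h/mL, with an estimated range from 450 ng.h/mL to 3600 ng.h/mL.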

Compound 4, area under the concentration-time curve: 1400 ng.h/mL
Compound 4: middle estimate off by 1.1-fold (0.03 log units), on the low side; low and high end bracket the measured number.
By their numbers in this assay, from the lowest: compounds 2, 4 and 3 (each within the scatter of the next, the first and the last beyond it); then compound 1.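

In this assay, the group of 12 heavy atoms in place of the group of 10 heavy atoms gives a 1.3-fold higher number from compound 2 to compound 4 (0.10 log units; within the scatter), so this swap on the saturated chain carbon does not separate the two compounds. Among the compounds shown here, this is the first reading at this position, and it shows that the larger group is tolerated here, with exposure staying in the same range, unlike the changes from compound 1 to compound 2 and from compound 2 to compound 3, which were both beyond the scatter. No supporting measurement is available to explain this result.

This single swap says nothing about how a group carrying an amine or a carboxylic acid would behave at this position. From the compounds shown here alone, whether the same swap would leave exposure unchanged on the bromo compound, compound 1, also remains open.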